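The source may hold more compounds than are shown below. What is called first, only, known or untested is meant among the compounds shown, and "the series" means these compounds.

Measured compounds in a functional assay on K562 cells (Homo sapiens) for inhibition, read by trypan blue exclusion, with a stated time of 72 h; on this read-out higher numbers stand for weaker inhibition and lower numbers for stronger inhibition:
compound 1, `Cn1c(=O)c(S(=O)(=O)c2ccc(F)cc2F)cc2cnc(Nc3ccc4cc[nH]c4c3)nc21`: 5000 nM
compound 2, `Cn1c(=O)c(S(=O)(=O)c2ccc(F)cc2F)cc2cnc(Nc3cccc4[nH]ccc34)nc21`: 1500 nM
compound 3, `Cn1ccc2cc(Nc3ncc4cc(S(=O)(=O)c5ccc(F)cc5F)c(=O)n(C)c4n3)ccc21`: 750 nM

Compound 3 gives the lowest of the three numbers; compound 2 sits within the scatter of it, while compound 1 lies beyond it, a 6.7-fold lower number from compound 1 to compound 3 (0.82 log units; beyond the scatter). Compound 4, `Cn1c(=O)c(S(=O)(=O)c2ccc(F)cc2F)cc2cnc(Nc3ccc4[nH]ncc4c3)nc21`, has yet to be measured in this assay. Its difference from compound 3 is 1H-indazol-5-yl in place of 1-methyl-1H-indol-5-yl on a nitrogen on an aromatic ring. For the measured compounds named here, no measured step bears directly on this change: the steps of a 6.7-fold lower number from compound 1 to compound 3 (0.82 log units; beyond the scatter) and a 2.0-fold lower number from compound 2 to compound 3 (0.30 log units; within the scatter) each alter the attachment of the indole and add the methyl together, and a 3.3-fold lower number from compound 1 to compound 2 (0.52 log units; beyond the scatter) alters only the attachment; none of them separates a ring carrying a hydrogen-bond donor from one without it at a fixed attachment. The two compounds whose ring carries a hydrogen-bond donor, compound 1 and compound 2, give the two higher numbers, which weakly suggests a higher number for compound 4. For compound 4 a modest rise is therefore expected, a 2.0-fold higher number from compound 3 to compound 4 (0.30 log units; within the scatter), so that its value in this assay is estimated at 1500 nM, with a range from 500 nM to 5000 nM.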

Compound 4, half-maximal inhibitory concentration: 50000 nM
Estimate against measurement, compound 4: 33-fold (1.52 log units) below; measured number above the stated range.
By their numbers in this assay, from the lowest: compounds 3 and 2 (each within the scatter of the next); then compound 1; then compound 4.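

In this assay the 1H-indazol-5-yl on the nitrogen gives the largest steps in the series, with a 67-fold higher number from compound 3 to compound 4 (1.82 log units; beyond the scatter) and a 33-fold higher number from compound 2 to compound 4 (1.52 log units; beyond the scatter) and, smaller but still beyond the scatter, a 10-fold higher number from compound 1 to compound 4 (1.00 log units; beyond the scatter). The 5-yl attachment shared with compound 3 therefore does not by itself keep the number low, and a hydrogen-bond donor in the entering ring does not set the size of the change, as compound 2 stands within the scatter of compound 3 despite carrying one. Nothing available explains the large rise for compound 4.

As far as these compounds go, this step combines a change of ring atoms with the loss of the methyl, so their separate contributions remain open. 1H-indol-5-yl and 1-methyl-1H-indazol-5-yl at this position would separate the two.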